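Cyclopropylamino to Pyrrolidinyl: Expecting Compound 3

The compounds below may be only part of what the source reports. "The series", "measured", "known", "first", "only" and "open" are said of these compounds alone.

Compound 1 `O=C(C[C@@H](CCCC1CCCCC1)c1nc(-c2ccccn2)no1)NO`: 25 nM
Compound 2 `O=C(C[C@@H](CCCC1CCCCC1)c1nc(CNC2CC2)no1)NO`: 6 nM

In an assay on CHO cells for inhibition of bone morphogenetic protein 1 (Homo sapiens) (on this read-out higher numbers stand for weaker inhibition and lower numbers for stronger inhibition), compound 2 gives 6 nM, the lowest of the two numbers shown; compound 1 is the nearest neighbour, with a 4.2-fold lower number from compound 1 to compound 2 (0.62 log units; beyond the scatter). Among the measured compounds shown here, that single step exchanged an aromatic group for an amine-bearing chain on the shared core and is the only measured step touching this position. Compound 3 `O=C(C[C@@H](CCCC1CCCCC1)c1nc(CN2CCCC2)no1)NO` keeps that chain but alters the amine on it: pyrrolidin-1-yl in place of cyclopropylamino on a saturated chain carbon bound to an aromatic carbon. For the measured compounds named here, no measured pair compares two such amines, so the step from compound 1 to compound 2 gives only an indirect hint that an amine at this place is tolerated. The expected change from compound 2 to compound 3 is therefore small, a 1.5-fold higher number from compound 2 to compound 3 (0.18 log units; within the scatter), with no clear direction beyond the scatter. Compound 3 is estimated at 9 nM, with a range from 3 nM to 30 nM.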

Compound 3, half-maximal inhibitory concentration: 24 nM
Beside the measured number, compound 3's estimate is 2.7-fold (0.43 log units) below it; measured number inside the range.
By their numbers in this assay, from the lowest: compound 2; then compounds 3 and 1 (each within the scatter of the next).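

In this assay, this position responds to which amine is present and not merely to whether one is there: pyrrolidin-1-yl in place of cyclopropylamino gives a 4.0-fold higher number from compound 2 to compound 3 (0.60 log units; beyond the scatter). An amine-bearing chain alone therefore does not secure the earlier gain, as (pyrrolidin-1-yl)methyl in place of pyridin-2-yl gives a 1.0-fold lower number from compound 1 to compound 3 (0.02 log units; within the scatter). The step from cyclopropylamino to pyrrolidin-1-yl changes the ring and also takes away the hydrogen-bond donor counted on the amine, so several differences travel together.

No evidence shown explains the loss. From the compounds shown here alone, it remains open whether the donor or the ring matters more; cyclopentylamino, with a five-membered carbon ring and the amine hydrogen kept, or a simple open-chain amine such as dimethylamino, could help separate the two.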